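A few compounds are considered here, and "the series" means these few. Any claim that something is new, unique, unknown or untested is made for them only; others in the source may bear on it.

In a functional assay on MCF7 cells (Homo sapiens) for cytotoxicity, read by MTT assay, with a stated time of 96 h (on this read-out lower numbers stand for stronger inhibition and higher numbers for weaker inhibition), three compounds sharing one core have been measured. Compound 1 (`COc1cc(C(=O)c2cn(-c3ccc(C)cc3)cc2-c2ccccc2F)cc(OC)c1OC`) gives 44 nM, compound 3 (`COc1cc(C(=O)c2cn(-c3ccc(C)cc3)cc2-c2cccc(N)c2)cc(OC)c1OC`) gives 53 nM, and compound 2 (`COc1cc(C(=O)c2cn(-c3ccc(C)cc3)cc2-c2ccc([N+](=O)[O-])cc2)cc(OC)c1OC`) gives 200 nM, the highest number of the three. The data show a 1.2-fold higher number from compound 1 to compound 3 (0.08 log units; within the scatter), which lies within the scatter, against a 4.5-fold higher number from compound 1 to compound 2 (0.66 log units; beyond the scatter) and a 3.8-fold lower number from compound 2 to compound 3 (0.58 log units; beyond the scatter), both modest.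

Compound 4 (`COc1cc(C(=O)c2cn(-c3ccc(N)cc3)cc2-c2ccc([N+](=O)[O-])cc2)cc(OC)c1OC`) keeps the 4-nitrophenyl group of compound 2 and changes elsewhere: amino in place of methyl on an aromatic carbon. This is amino in place of methyl on an aromatic carbon, turning 4-methylphenyl into 4-aminophenyl. Going by the values given here, none of the measured steps touches this place, since all three only exchange 2-fluorophenyl, 4-nitrophenyl and 3-aminophenyl among themselves. They offer no direct guide, and the largest of them, a 4.5-fold higher number from compound 1 to compound 2 (0.66 log units; beyond the scatter), serves only as a rough measure of how far one change has moved the number in this small set. The estimated change is a 1.3-fold lower number from compound 2 to compound 4 (0.12 log units; within the scatter), so no step beyond the scatter is expected. For compound 4 the expected value is 150 nM, within an estimated range of 40 nM to 600 nM.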

Compound 4, half-maximal inhibitory concentration: 260 nM
Estimate against measurement, compound 4: 1.7-fold (0.24 log units) below; low and high end bracket the measured number.
By their numbers in this assay, from the lowest: compounds 1 and 3 (each within the scatter of the next); then compounds 2 and 4 (each within the scatter of the next).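

In this assay, the step at the 4-methylphenyl group (a 1.3-fold higher number from compound 2 to compound 4 (0.11 log units; within the scatter)) is the only one shown at this position, and it stays within the scatter. With the 4-nitrophenyl group held in place, then, amino in place of methyl on this aromatic carbon, para to a large group, shows no measurable difference in the number, even though the amino group carries a hydrogen-bond donor and acceptor that the methyl group lacks. No measured evidence is available to account for this result.

The compounds shown leave open whether the same exchange would also stay within the scatter alongside the 2-fluorophenyl group of compound 1 or the 3-aminophenyl group of compound 3. They also leave open how other groups at this position, such as a methoxy group, a hydroxyl group or a carboxylic acid, would compare.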